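The source may hold more compounds than are shown below. What is called first, only, known or untested is meant among the compounds shown, and "the series" means these compounds.

Working notes on the series. Three compounds carry the same core with varied aryl substituents. In a functional assay, read by spectrophotometry, with a stated time of 60 min, tested at 60 uM (a lower number here means a weaker effect, a higher number a stronger effect of the compound at the concentration tested), compound 1 `COc1cc(OC)cc(-n2c(-c3ccccc3)nc(C)c2C)c1` gives 54%. Compound 2 `COc1ccc(-n2c(-c3ccc(F)cc3)nc(C)c2C)cc1` gives 48.3% in this assay, and compound 3 `COc1ccc(-n2c(-c3ccccc3)nc(C)c2C)cc1` gives 48.3%. Compound 1 thus stands at the top of the three numbers, but its distance to compound 2 and to compound 3 lies within the usual scatter, so the three values cannot be told apart.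

Compound 4 `COc1cc(OC)cc(-n2c(-c3ccc(F)cc3)nc(C)c2C)c1` has not yet been measured. It differs from compound 1 as follows: fluoro in place of hydrogen on an aromatic carbon. Among the compounds with values here, the one measured step that bears on this change is the same exchange taken in the other direction, no change at the digits printed from compound 2 to compound 3 (within the scatter), which gave no movement beyond the scatter. On that basis the step from compound 1 to compound 4 is expected to be no change at the digits printed from compound 1 to compound 4 (within the scatter), no change beyond the scatter. Compound 4 is therefore estimated at 54% in this assay, with a range from 42% to 66%.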

Compound 4, a percentage reported as activity, at one concentration (the size of the read-out at that concentration, not a potency): 57.5%
Estimate against measurement, compound 4: 3.5 percentage points below; measured number inside the range.
By their numbers in this assay, from the lowest: compounds 2, 3, 1 and 4 (each within the scatter of the next).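

In this assay, fluoro in place of hydrogen on an aromatic carbon, para to a large group, gives a number 3.5 percentage points higher from compound 1 to compound 4 (within the scatter), so the change can now be read on the core of compound 1 as well as on that of compound 2. At this position, neither core shows a movement beyond the scatter, and phenyl and 4-fluorophenyl cannot be told apart by this read-out. The two readings also agree with each other: the same change on two cores in this assay, no change at the digits printed (within the scatter) from compound 2 to compound 3 and a number 3.5 percentage points lower (within the scatter) from compound 4 to compound 1, 3.5 percentage points apart, within the scatter of two such steps

From the compounds shown here alone, it remains open whether any group at this position moves the read-out beyond the scatter, as an amine, a carboxylic acid or a longer chain on the same aromatic carbon could show. Each number is also the size of the read-out at a single concentration, so these compounds say nothing about potency.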